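This account rests on a few compounds, and the source may have more. Where it says the series, first, only, none or still open, it means among the compounds named here.

Measured compounds in a functional assay on HL-60 cells (Homo sapiens) for cytotoxicity, read by MTT assay; a lower number here means a stronger inhibitor, a higher number a weaker inhibitor:
Compound 1 `O=C1CCC(N2C(=O)C(c3ccccc3)=C(c3ccccc3)C2=O)C(=O)N1` gives > 50000 nM, a limit of the assay.
Compound 2 `CN(C)CCN1C(=O)CCC(N2C(=O)C(c3ccccc3)=C(c3ccccc3)C2=O)C1=O` gives > 50000 nM, also a limit.
Compound 3 `CN(C)CCN1C(=O)CCC(N2C(=O)c3ccccc3C2=O)C1=O` gives > 50000 nM, again a limit.

Compound 1 therefore stands only at the limit, with no number of its own, and the same holds for the two other measured compounds, as the limit of > 50000 nM in this assay, at which 3 of the 3 values shown sit, shows. Among the compounds with values here, the one step among them, a step that the two limits leave unreadable from compound 1 to compound 2, is unreadable from two limits. Compound 4 `NC(=O)CCC(C(=O)O)N1C(=O)C(c2ccccc2)=C(c2ccccc2)C1=O` differs from compound 1 by 3-carbamoyl-1-carboxypropyl in place of 2,6-dioxopiperidin-3-yl on an amide-type nitrogen in a ring. Within the data shown here, no measured step bears on this change, so the only guide is that every measured value sits at the limit. Compound 4 is therefore expected to stay there as well, with a step that the limit leaves unreadable from compound 1 to compound 4 that cannot be read as a direction. Compound 4 is estimated at 100000 nM, within 30000 nM to 500000 nM.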

Compound 4, half-maximal inhibitory concentration: > 50000 nM
Compound 4: only a limit was reported (the forecaster's own chance of this, stated with the estimate: 85%); the middle value does not contradict the limit.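

No step can be read between compound 1 and compound 4, as both values are limits and not numbers: the limit of > 50000 nM in this assay, at which 4 of the 4 values shown sit.

For this assay the compounds shown leave open whether any change to the core of compound 1 gives a number rather than a limit.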